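The source may hold more compounds than are shown below. What is called first, only, known or untested is meant among the compounds shown, and "the series" means these compounds.

Measured compounds:
- compound 1 `Cc1cccnc1Nc1nc(SCc2ccc(C(=O)Nc3ccccc3N)cc2)nn2cccc12` — 1370 nM
- compound 2 `Nc1cc(F)ccc1NC(=O)c1ccc(CSc2nc(Nc3cc[nH]n3)c3cccn3n2)cc1` — 731 nM
- compound 3 `Cc1cc(Nc2nc(SCc3ccc(C(=O)Nc4ccc(F)cc4N)cc3)nn3cccc23)n[nH]1` — 75.1 nM

In a functional assay on HCT-116 cells (Homo sapiens) for antiproliferative activity, read by luminescence, with a stated time of 72 h, tested at 1 uM (on this read-out higher numbers stand for weaker inhibition and lower numbers for stronger inhibition), compound 3 gives the lowest number of the three; compound 2 sits nearest, at 731 nM, and compound 1 furthest, at 1370 nM. Going by the values given here, the one single-point step in the set is a 9.7-fold lower number from compound 2 to compound 3 (0.99 log units; beyond the scatter), which shows that the group on the amine nitrogen matters for this read-out.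

Compound 4 `Cc1cccnc1Nc1nc(SCc2ccc(C(=O)Nc3ccc(F)cc3N)cc2)nn2cccc12` is the next analogue. The change from compound 3 is 3-methylpyridin-2-yl in place of 5-methyl-1H-pyrazol-3-yl on a nitrogen on an aromatic ring. Among the compounds with values here, no measured step covers exactly this swap. Compound 1 carries the same 3-methylpyridin-2-yl amine as compound 4 but lacks the fluorine on the benzenediamine, so compound 1 and compound 3 differ in two places and only their two values can be compared: compound 1 gives 1370 nM against compound 3 at 75.1 nM. On that basis the pyrazole-to-pyridine exchange is expected to cost potency, and compound 4 is expected to land near compound 1, with a 12-fold higher number from compound 3 to compound 4 (1.08 log units; beyond the scatter) as the estimated step. The expected value for compound 4 is 900 nM, with a range of 300 nM to 3000 nM.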

Compound 4, half-maximal inhibitory concentration: 857 nM
For compound 4 the middle estimate is 1.1-fold (0.02 log units) above the measured one, within the range that was stated.
By their numbers in this assay, from the lowest: compound 3; then compounds 2, 4 and 1 (each within the scatter of the next).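

In this assay, the exchange of 5-methyl-1H-pyrazol-3-yl for 3-methylpyridin-2-yl on the nitrogen gives an 11-fold higher number from compound 3 to compound 4 (1.06 log units; beyond the scatter), so this position also responds to a change of the whole ring, not only to the methyl step seen earlier. With a 1.2-fold higher number from compound 2 to compound 4 (0.07 log units; within the scatter), 3-methylpyridin-2-yl and 1H-pyrazol-3-yl are not separated, which leaves 5-methyl-1H-pyrazol-3-yl alone apart from the other two groups on this nitrogen. With the 3-methylpyridin-2-yl amine in place, fluoro in place of hydrogen gives a 1.6-fold lower number from compound 1 to compound 4 (0.20 log units; within the scatter), so it is not separated from hydrogen in this pair.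

As far as these compounds go, whether an ethyl or cyclopropyl group on the pyrazole in place of the methyl would hold or extend the value of compound 3 remains open. No measured finding accounts for the gap between these amine groups.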